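Same ester swap on a different core: an expected shift

The source may hold more compounds than are shown below. What is called first, only, known or untested is meant among the compounds shown, and "the series" means these compounds.

Compound 1 `C=C1[C@H](OC(C)=O)[C@@H](OC(=O)C(C)(C)C)[C@@H](OC(C)=O)C(C)(C)/C=C/[C@H](C)[C@H](OC(=O)c2ccccc2)[C@@]2(O)C[C@@](C)(O)[C@H](OC(C)=O)[C@@H]2[C@H]1OCC(C)C` and compound 2 `C=C1[C@H](OC(C)=O)[C@@H](OC(=O)c2cccc(C)c2)[C@@H](OC(C)=O)C(C)(C)/C=C/[C@H](C)[C@H](OC(=O)c2ccccc2)[C@@]2(O)C[C@@](C)(O)[C@H](OC(C)=O)[C@@H]2[C@H]1OCC(C)C` share one core and differ in a single ester. In a functional assay on NCI/ADR-RES cells (Homo sapiens) for positive allosteric modulation, read by MTT assay, with a stated time of 48 h, tested at 10 uM (on this read-out lower numbers stand for stronger inhibition and higher numbers for weaker inhibition), compound 1 gives 1220 nM and compound 2 gives 980 nM. The change between them is 3-methylphenyl in place of tert-butyl on a carbonyl carbon and it made a 1.2-fold lower number from compound 1 to compound 2 (0.10 log units; within the scatter), so the two values cannot be told apart.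

Compound 3 `C=C1[C@H](OC(C)=O)[C@@H](OC(C)=O)[C@@H](OC(C)=O)C(C)(C)/C=C/[C@H](C)[C@H](OC(=O)c2ccccc2)[C@@]2(O)C[C@@](C)(OC(=O)C(C)(C)C)[C@H](OC(C)=O)[C@@H]2[C@H]1OCC(C)C` has a different core, and the difference between the two cores is not broken down here. In this assay compound 3 gives 500 nM. Compound 4 `C=C1[C@H](OC(C)=O)[C@@H](OC(C)=O)[C@@H](OC(C)=O)C(C)(C)/C=C/[C@H](C)[C@H](OC(=O)c2ccccc2)[C@@]2(O)C[C@@](C)(OC(=O)c3cccc(C)c3)[C@H](OC(C)=O)[C@@H]2[C@H]1OCC(C)C` is compound 3 with the same change applied: 3-methylphenyl in place of tert-butyl on a carbonyl carbon. The surroundings of the carbonyl carbon read the same in both cases. This is the same change, not merely the same kind.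

The expectation for compound 4 rests on compound 1 and compound 2, whose step a 1.2-fold lower number from compound 1 to compound 2 (0.10 log units; within the scatter) was small. Compound 4 is therefore expected to sit close to compound 3, with an estimated step of a 1.2-fold lower number from compound 3 to compound 4 (0.08 log units; within the scatter). The estimated value for compound 4 in this assay is 420 nM, expected to lie between 200 nM and 900 nM.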

Compound 4, half-maximal inhibitory concentration: 1510 nM
Estimate against measurement, compound 4: 3.6-fold (0.56 log units) below; measured number outside the range, above it.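

In this assay, the swap of tert-butyl for 3-methylphenyl on the carbonyl carbon did not carry over from one core to the other, and the two steps differ by more than repeat measurements would normally explain: the same change on two cores in this assay, a 1.2-fold lower number (0.10 log units; within the scatter) from compound 1 to compound 2 and a 3.0-fold higher number (0.48 log units; beyond the scatter) from compound 3 to compound 4, 3.8-fold (0.58 log units) apart, beyond the scatter of two such steps. On the core of compound 3 the swap gave a 3.0-fold higher number from compound 3 to compound 4 (0.48 log units; beyond the scatter), which here means weaker inhibition, while on the core of compound 1 it gave no change that can be told apart from scatter. This shows that a step measured on one core was a poor guide to the other in this series, but two pairs are too few for a general rule, and they do not show which difference between the cores matters or why.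

Going by these compounds, it remains open whether the weaker result on the core of compound 3 is specific to 3-methylphenyl or would also appear with another group on that carbonyl carbon, such as a longer chain or an amine. A third core could also behave like either pair or like neither.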